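The compounds below may be only part of what the source reports. "The series", "measured", "known", "first", "only" and "open" are said of these compounds alone.

In a functional assay on PANC-1 cells (Homo sapiens) for antiproliferative activity, read by fluorescence and resazurin assay, with a stated time of 48 h (on this read-out lower numbers stand for stronger inhibition and higher numbers for weaker inhibition), compound 1 `CCOc1ccc2nc(Cl)c(/C=N/NC(=O)c3cc4ccc(O)cc4oc3=O)cc2c1` gives 129 nM, compound 2 `O=C(N/N=C/c1ccncc1)c1cc2cc(Br)ccc2oc1=O` gives 25700 nM, and compound 3 `O=C(N/N=C/c1cccnc1)c1cc2cc(Br)ccc2oc1=O` gives 8350 nM. Compound 3 therefore stands second highest of the three numbers, nearest to compound 2 and far from compound 1. Going by the values given here, the one step recorded, a 3.1-fold lower number from compound 2 to compound 3 (0.49 log units; beyond the scatter), moved the pyridine nitrogen and says nothing about the bromo group. Compound 4 `O=C(N/N=C/c1cccnc1)c1cc2ccccc2oc1=O` differs from compound 3 in one place: hydrogen in place of bromo on an aromatic carbon. Among the compounds with values here, no measured pair isolates this change, and compound 1 differs from compound 3 in several places at once, so it offers no guide either. For this assay the estimate for compound 4 is 11000 nM, within 3500 nM to 35000 nM, which means an expected step of a 1.3-fold higher number from compound 3 to compound 4 (0.12 log units; within the scatter), not beyond the scatter.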

Compound 4, half-maximal inhibitory concentration: 15300 nM
The estimate for compound 4 lay 1.4-fold (0.14 log units) below the measured number; the measured number falls inside the stated range.
By their numbers in this assay, from the lowest: compound 1; then compounds 3, 4 and 2 (each within the scatter of the next, the first and the last beyond it).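

Putting hydrogen in place of bromo on this aromatic carbon gives a 1.8-fold higher number from compound 3 to compound 4 (0.26 log units; within the scatter) in this assay. Going by these compounds alone, this is the first direct reading of this position: with the pyridin-3-yl group held fixed, compound 3 and compound 4 cannot be told apart, so this change alone shows no measurable effect. No measurement at hand offers an explanation for this result. Still open, as far as these compounds go, is whether an amine or a carboxylic acid on this carbon would shift the number beyond the scatter. Also open, from the compounds shown here alone, is whether the same change would read alike with the pyridin-4-yl group of compound 2.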